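This account rests on a few compounds, and the source may have more. Where it says the series, first, only, none or still open, it means among the compounds named here.

In a functional assay on HT cells (Homo sapiens) for antiproliferative activity, read by fluorescence, with a stated time of 72 h (a higher number here means a weaker inhibitor of growth, a lower number a stronger inhibitor of growth), compound 1 `CC(C)c1n[nH]c2c(NCc3ccc(-c4ccccn4)cc3)nc(SCC(N)CN)nc12` gives 480 nM and compound 3 `CC(C)c1n[nH]c2c(NCc3ccc(-c4ccccn4)cc3)nc(SCC(O)C(F)(F)F)nc12` gives 690 nM while compound 2 `CC(C)c1n[nH]c2c(NCc3ccc(-c4ccccn4)cc3)nc(SCC3CNC(=O)O3)nc12` gives 80 nM as the lowest of the three numbers. Compound 4 `CC(C)c1n[nH]c2c(NCc3ccc(-c4ccccn4)cc3)nc(SCC(C)(C)O)nc12` keeps the shared core and differs from compound 2 in one group, with 1-hydroxy-1-methylethyl in place of 2-oxo-1,3-oxazolidin-5-yl on a saturated chain carbon bound to a sulfur as the whole change. Two measured steps involve the departing 2-oxo-1,3-oxazolidin-5-yl group: a 6.0-fold lower number from compound 1 to compound 2 (0.78 log units; beyond the scatter) with 1,2-diaminoethyl as the other group, and an 8.6-fold higher number from compound 2 to compound 3 (0.94 log units; beyond the scatter) with 2,2,2-trifluoro-1-hydroxyethyl as the other group. Like the entering 1-hydroxy-1-methylethyl, neither of those groups has a ring. The remaining step, a 1.4-fold higher number from compound 1 to compound 3 (0.16 log units; within the scatter) between those two groups, lies within the scatter. Both compounds without the ring have clearly higher numbers than compound 2, so a clear rise is expected in this assay for compound 4, of somewhat smaller size than those two steps. The expected change is a 4.4-fold higher number from compound 2 to compound 4 (0.64 log units; beyond the scatter) in this estimate. Among the compounds with values here, no measured compound carries 1-hydroxy-1-methylethyl, so the range stays wide. For compound 4 the estimated value is 350 nM with an expected range from 130 nM to 900 nM in this measurement.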

Compound 4, concentration for 50% growth inhibition: 507 nM
Estimate against measurement, compound 4: 1.4-fold (0.16 log units) below, and the stated range covers the measured number.
By their numbers in this assay, from the lowest: compound 2; then compounds 1, 4 and 3 (each within the scatter of the next).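

In this assay, a third group without a ring, on a saturated chain carbon bound to a sulfur, again gives a clearly higher number than the 2-oxo-1,3-oxazolidin-5-yl group, with a 6.3-fold higher number from compound 2 to compound 4 (0.80 log units; beyond the scatter). The other two steps, a 1.4-fold lower number from compound 3 to compound 4 (0.13 log units; within the scatter) and a 1.1-fold higher number from compound 1 to compound 4 (0.02 log units; within the scatter), show that 1-hydroxy-1-methylethyl, 2,2,2-trifluoro-1-hydroxyethyl and 1,2-diaminoethyl sit at one level, so among these four compounds only the ring-bearing compound 2 stands apart. Nothing measured here explains that gap.

On these data alone, what stays open is whether the low number belongs to the ring as such or to the carbonyl and nitrogen within it. A tetrahydrofuran-2-yl ring and an open-chain carbamate, each on a saturated chain carbon bound to a sulfur, would help separate those two readings.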